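Acid, ester and naphthyl amides: cytotoxicity notes

The source may report more compounds than this note shows. Statements on the series, on what has been measured and on what is new or still open speak of the compounds shown alone.

Compound 1 `CC(C)N(Cc1cccc(OCCCCCC(=O)O)c1)C(=O)c1ccccc1` and compound 2 `CCOC(=O)CCCCCOc1cccc(CN(C(=O)c2ccccc2)C(C)C)c1` differ only by ethyl in place of hydrogen on an oxygen next to a carbonyl group. In an ADME assay on Raji cells (Homo sapiens) for cytotoxicity, read by CellTiter-Glo and resazurin assay, with a stated time of 72 h (a higher number here means that more compound is needed for the effect, a lower number that less compound is needed), compound 1 gives only a limit, > 26000 nM. In this assay compound 2 likewise gives only a limit, > 26000 nM. The step that the two limits leave unreadable from compound 1 to compound 2 therefore cannot be sized; the limit of > 26000 nM in this assay, at which 2 of the 2 values shown sit, is all the two values show. Compound 3 `CCOC(=O)CCCCCOc1cccc(CN(C(=O)c2ccc(-c3cccc4ccccc34)cc2)C(C)C)c1` carries the change (naphthalen-1-yl in place of hydrogen on an aromatic carbon). Among the compounds with values here, no measured step speaks to this change, so no direction beyond the scatter can be drawn from compound 2. Compound 3 is expected to stay near the limit, at 18000 nM (range 5000 nM to 40000 nM), a step of an at least 1.4-fold lower number from compound 2 to compound 3 (0.15 log units; that floor lies within the scatter).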

Compound 3, half-maximal effective concentration: > 26000 nM
Compound 3: no number, only a limit (the forecaster's own chance of this, stated with the estimate: 55%); middle value at least 1.4-fold (0.15 log units) from the limit.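

In this assay, within the data shown here, compound 2 and compound 3 both give only limits, so no step between them can be read. Open, from the compounds shown here alone, is whether naphthalen-1-yl on the aromatic carbon changes the read-out at all.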